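Replacing carboxy with diethylsulfamoyl in a rat inhibition series

The source may hold more compounds than are shown below. What is called first, only, known or untested is meant among the compounds shown, and "the series" means these compounds.

Compound 1 `CCOc1cccc(-c2ncc(C(=O)O)c(=O)[nH]2)c1` gives 5 mg/kg
Compound 2 `CCOc1ccc(C(=O)O)cc1-c1ncc(C(=O)O)c(=O)[nH]1` gives 25 mg/kg

In a functional assay on the whole organism (strain Sprague-Dawley) for inhibition, with Rattus norvegicus as the target, with a stated time of 10 min (a lower number here means that less compound is needed, a higher number that more compound is needed for the effect), compound 2 gives 25 mg/kg as the higher of the two numbers, and compound 1 gives 5 mg/kg as the lower. The gap between these two numbers lies beyond the scatter. Going by the values given here, compound 3 `CCOc1ccc(S(=O)(=O)N(CC)CC)cc1-c1ncc(C(=O)O)c(=O)[nH]1` has diethylsulfamoyl in place of carboxy on an aromatic carbon (para to an ethoxy group) diethylsulfamoyl in place of carboxy on an aromatic carbon as its only difference from compound 2. Among the compounds with values here, no measured pair shows this change alone, so the expectation is uncertain. A moderate move toward a lower dose is expected, beyond the scatter, with a 2.5-fold lower number from compound 2 to compound 3 (0.40 log units; beyond the scatter) as the estimated step. In this assay compound 3 is estimated at 10 mg/kg within a range of 2.5 mg/kg to 40 mg/kg as the expected dose.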

Compound 3, dose for 50% inhibition: 40 mg/kg
Estimate against measurement, compound 3: 4.0-fold (0.60 log units) below; low and high end bracket the measured number.
By their numbers in this assay, from the lowest: compound 1; then compounds 2 and 3 (each within the scatter of the next).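

In this assay, a 1.6-fold higher number from compound 2 to compound 3 (0.20 log units; within the scatter) follows when diethylsulfamoyl takes the place of carboxy on the aromatic carbon para to an ethoxy group. This position therefore accepts a much larger group that has no hydrogen-bond donor, and the two groups cannot be told apart by this dose. What the compounds shown leave open is whether an amine or a longer alkyl chain here would also stay within the scatter of compound 2. Nothing measured here explains why carboxy and diethylsulfamoyl read alike.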